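Taking the furan-2-yl out of compound 2

The source may hold more compounds than are shown below. What is called first, only, known or untested is meant among the compounds shown, and "the series" means these compounds.

Values so far in an ADME assay on the whole organism (Rattus norvegicus, strain Sprague-Dawley) for pharmacokinetics, read by LC-MS, with a stated time of 360 min, at a dose of 0.5 mg/kg by the intravenous route; a lower number here means slower removal, a higher number faster removal of the compound
Compound 1 `CC(C)N1CN(C(c2ccccc2)c2ccccc2)n2ccc(=O)c(O)c2C1=O` gives 10.9 mL/min/kg
Compound 2 `O=C1c2c(O)c(=O)ccn2N(C(c2ccccc2)c2ccccc2)CN1Cc1ccco1` gives 42.6 mL/min/kg

Among the measured compounds shown here, compound 2 stands highest of the two, and compound 1 holds the only other number. For the measured compounds named here, the single measured step is a 3.9-fold higher number from compound 1 to compound 2 (0.59 log units; beyond the scatter) in which (furan-2-yl)methyl takes the place of isopropyl on an amide-type nitrogen in a ring.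

Compound 3 `CN1CN(C(c2ccccc2)c2ccccc2)n2ccc(=O)c(O)c2C1=O` has not yet been measured. Its difference from compound 2 is hydrogen in place of furan-2-yl on a saturated chain carbon bound to an amide-type nitrogen in a ring and in words it is hydrogen in place of furan-2-yl on a saturated chain carbon bound to an amide-type nitrogen in a ring, which turns (furan-2-yl)methyl into methyl.

The measured step bears on this change, as it falls on the same nitrogen. Compound 1, which has no furan-2-yl, gives 10.9 mL/min/kg so a return toward that number is expected. The expected change is a 2.7-fold lower number from compound 2 to compound 3 (0.43 log units; beyond the scatter) and so a lower number, similar in size to the measured step but less certain, resting on that step alone. For compound 3 the estimated value is 16 mL/min/kg with an expected range from 7 mL/min/kg to 38 mL/min/kg.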

Compound 3, clearance: 18.8 mL/min/kg
For compound 3 the middle estimate is 1.2-fold (0.07 log units) below the measured one; the measured number falls inside the stated range.
By their numbers in this assay, from the lowest: compounds 1 and 3 (each within the scatter of the next); then compound 2.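

In this assay, the step of a 2.3-fold lower number from compound 2 to compound 3 (0.36 log units; beyond the scatter) shows that losing furan-2-yl from the saturated chain carbon bound to an amide-type nitrogen in a ring goes with a change beyond the scatter, so the number of compound 2 now stands apart from those with methyl as well as isopropyl at this nitrogen. The step of a 1.7-fold higher number from compound 1 to compound 3 (0.24 log units; within the scatter) lies within the scatter, so this assay does not separate methyl from isopropyl here, and among these three compounds only the one with (furan-2-yl)methyl stands apart, with none going against that reading. Nothing available explains why this change goes with the shift in clearance.

The compounds shown leave open whether the higher number belongs to furan-2-yl itself or would come with another ring on the same chain carbon, such as the phenyl ring of a benzyl group or the saturated ring of a (tetrahydrofuran-2-yl)methyl group. They also leave open how a longer chain such as n-butyl, or a chain ending in an amine, would stand at this nitrogen.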